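Moving the chlorine around the phenyl ring: compound 3

The source may hold more compounds than are shown below. What is called first, only, known or untested is meant among the compounds shown, and "the series" means these compounds.

Measured so far:
Compound 1, `CC(=O)N1N=C(c2ccc(O)cc2)CC1c1ccccc1Cl`: 8.6 nM
Compound 2, `CC(=O)N1N=C(c2ccc(O)cc2)CC1c1cccc(Cl)c1`: 10 nM

Both compounds were tested in an assay on isolated protein for inhibition of Amine oxidase [flavin-containing] A (Homo sapiens); a higher number here means a weaker inhibitor, a lower number a stronger inhibitor. Compound 1 gives 8.6 nM, and compound 2, which carries the chlorine on a different position of the same phenyl ring, gives 10 nM; the two numbers lie within the usual scatter of each other, so neither compound can be called the stronger inhibitor on these data. The step from compound 1 to compound 2 is a 1.2-fold higher number from compound 1 to compound 2 (0.07 log units; within the scatter).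

Compound 3, `CC(=O)N1N=C(c2ccc(O)cc2)CC1c1ccc(Cl)cc1`, has not been measured. It differs from compound 1 as follows: 4-chlorophenyl in place of 2-chlorophenyl on a saturated ring carbon. Within the data shown here, the only measured step that bears on this change is the one from compound 1 to compound 2, which also moved the chlorine on that ring and stayed within the scatter. A step of similar size is therefore expected here: the expected change from compound 1 to compound 3 in this assay is a 1.2-fold higher number from compound 1 to compound 3 (0.07 log units; within the scatter). Compound 3 is accordingly estimated at 10 nM, with a range from 3 nM to 35 nM.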

Compound 3, half-maximal inhibitory concentration: 100 nM
Compound 3: middle estimate off by 10-fold (1.00 log units), on the low side; measured number above the stated range.
By their numbers in this assay, from the lowest: compounds 1 and 2 (each within the scatter of the next); then compound 3.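

In this assay, the place of the chlorine on the phenyl ring does matter: 4-chlorophenyl in place of 2-chlorophenyl gives a 12-fold higher number from compound 1 to compound 3 (1.07 log units; beyond the scatter), and 4-chlorophenyl in place of 3-chlorophenyl gives a 10-fold higher number from compound 2 to compound 3 (1.00 log units; beyond the scatter). Compound 3 is therefore the weakest inhibitor of the three, although it has the same atoms as the other two, so the close match between compound 1 and compound 2 does not extend to every place on this ring. Nothing available here explains this loss of inhibition.

As far as these compounds go, it remains open whether the loss belongs to chlorine itself or to any group at this place, which a 4-fluorophenyl, 4-methoxyphenyl or 4-aminophenyl group could test. An unsubstituted phenyl group would also show how much the chlorine contributes in compound 1 and compound 2.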